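This account rests on a few compounds, and the source may have more. Where it says the series, first, only, none or still open, it means among the compounds named here.

Compound 1 `Cc1ccc2cc(CN(Cc3ccc(F)cc3)Cc3ccc(C(F)(F)F)cc3)c(=O)[nH]c2c1`: in a toxicity assay on MDCK cells (Canis lupus familiaris) for cytotoxicity, read by crystal violet staining, with a stated time of 48 h (a lower number here means that less compound is tolerated, a higher number that more compound is tolerated), compound 1 gives > 33000 nM, which is a limit of the assay and not a number.
Compound 2 `Cc1ccc2[nH]c(=O)c(CN(Cc3ccccc3)Cc3ccc(C(C)(C)C)cc3)cc2c1`: in this assay compound 2 gives > 5000 nM, again a limit of the assay and not a number.

Compound 2 therefore stands only at a limit, and the other value shown is a limit as well the limit of > 33000 nM in this assay, at which 1 of the 2 values shown sits (the limit of > 5000 nM in this assay, at which 1 of the 2 values shown sits). Among the measured compounds shown here, no step between measured compounds can be drawn, and the two values show no difference between compound 1 and compound 2.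

Compound 3 `Cc1ccc2[nH]c(=O)c(CN(Cc3ccc(C(N)=O)cc3)Cc3ccc(C(C)(C)C)cc3)cc2c1` has not yet been measured in this assay. It differs from compound 2 by carbamoyl in place of hydrogen on an aromatic carbon. The expected step from compound 2 to compound 3 in this assay is a step that the limit leaves unreadable from compound 2 to compound 3, which is no change beyond the usual scatter. For compound 3 the estimate in this assay is 20000 nM, with a range from 5000 nM to 60000 nM.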

Compound 3, half-maximal cytotoxic concentration: > 5000 nM
Compound 3 ended at the assay's limit (the forecaster's own chance of this, stated with the estimate: 70%); the middle value lies beyond the limit too.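

In this assay, among the compounds shown here, compound 3 gives > 5000 nM, a limit of the assay and not a number, so no step between compound 2 and compound 3 can be read. The compounds shown leave open whether carbamoyl in place of hydrogen changes the half-maximal cytotoxic concentration at all.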